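The source may hold more compounds than are shown below. What is called first, only, known or untested is meant among the compounds shown, and "the series" means these compounds.

Of the compounds shown here, three have been tested in a functional assay on the whole organism with Rattus norvegicus as the target; on this read-out higher numbers stand for weaker inhibition and lower numbers for stronger inhibition. Compound 1 `CC(C)(C)c1ccc(O)c(NCCCN2CCN(C(c3ccccc3)c3ccc(Cl)cc3)CC2)c1` gives 0.068 ug/mL in this assay. Compound 2 `CC(C)N(CCCN1CCN(C(c2ccccc2)c2ccc(Cl)cc2)CC1)c1cc(C(C)(C)C)ccc1O` differs from compound 1 in one place only, (isopropyl in place of hydrogen on a nitrogen on an aromatic ring), and in this assay compound 2 gives 0.39 ug/mL. That single change produced a 5.7-fold higher number from compound 1 to compound 2 (0.76 log units; beyond the scatter). Compound 3 `Cc1ccc(O)c(NCCCN2CCN(C(c3ccc(F)cc3)c3ccc(F)cc3)CC2)c1` is built on another core; how its core differs from that of compound 1 is not broken down here. In this assay compound 3 gives 0.1 ug/mL, a number within the scatter of compound 1, so those two cannot be told apart, while compound 2 stands well higher than compound 3.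

Compound 4 `Cc1ccc(O)c(N(CCCN2CCN(C(c3ccc(F)cc3)c3ccc(F)cc3)CC2)C(C)C)c1` has not yet been measured. It stands to compound 3 as compound 2 stands to compound 1: the change is isopropyl in place of hydrogen on a nitrogen on an aromatic ring, and the surroundings of the altered nitrogen are the same in both pairs. Within the data shown here, because the one earlier instance of this change gave a 5.7-fold higher number from compound 1 to compound 2 (0.76 log units; beyond the scatter), a step of similar size is expected here, with the caution that a single precedent on a different core is a thin basis. The expected step is a 5.0-fold higher number from compound 3 to compound 4 (0.70 log units; beyond the scatter). On that basis compound 4 is estimated at 0.5 ug/mL, with a likely range from 0.2 ug/mL to 1.3 ug/mL.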

Compound 4, half-maximal inhibitory concentration: 1.2 ug/mL
Compound 4: middle estimate off by 2.4-fold (0.38 log units), on the low side, within the range that was stated.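

In this assay, putting isopropyl in place of the hydrogen on the nitrogen gives a 12-fold higher number from compound 3 to compound 4 (1.08 log units; beyond the scatter), so inhibition weakens on this core as well. The step on this core looks larger, but the two steps point the same way and their sizes cannot be told apart: the same change on two cores in this assay, a 5.7-fold higher number (0.76 log units; beyond the scatter) from compound 1 to compound 2 and a 12-fold higher number (1.08 log units; beyond the scatter) from compound 3 to compound 4, 2.1-fold (0.32 log units) apart, within the scatter of two such steps

On these two cores, then, the change carries over in direction and, within the scatter, in size, so the step measured on one core was a fair guide to the step on the other; two pairs cannot show that this would hold on a further core, and they do not explain why the number rises.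

The compounds shown leave open whether a smaller group on this nitrogen, such as methyl or ethyl, would weaken inhibition as much as isopropyl does. They also leave open how an acetyl group or a longer chain such as n-butyl at the same place would behave on either core.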